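A few compounds are considered here, and "the series" means these few. Any claim that something is new, unique, unknown or untested is made for them only; others in the source may bear on it.

Measured so far in an assay on isolated protein for inhibition of Gonadotropin-releasing hormone receptor (Rattus norvegicus); a higher number here means a weaker inhibitor, a lower number a stronger inhibitor:
compound 1 `COc1ccc([N+](=O)[O-])cc1CSc1nc2cc(NC(=O)NC(C)(C)C)ccc2n1C1CC1`, 860 nM
compound 2 `CCCCn1c(SCc2cc([N+](=O)[O-])ccc2OC)nc2cc(NC(=O)NC(C)(C)C)ccc21`, 330 nM

Among the measured compounds shown here, compound 2 has the lowest of the two numbers in this assay, and the single step to it, a 2.6-fold lower number from compound 1 to compound 2 (0.42 log units; beyond the scatter), is modest but beyond the scatter. Compound 3 `COCCn1c(SCc2cc([N+](=O)[O-])ccc2OC)nc2cc(NC(=O)NC(C)(C)C)ccc21` differs from compound 2 by methoxy in place of ethyl on a saturated chain carbon, two bonds along the chain from an aromatic nitrogen. For the measured compounds named here, that same aromatic nitrogen is where the only measured step acted, yet swapping a ring for a chain is not a close model for this exchange, so it bears on it only loosely. The expected step is a 1.4-fold higher number from compound 2 to compound 3 (0.13 log units; within the scatter), within the scatter. Compound 3 is estimated at 450 nM with a range of 200 nM to 1100 nM.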

Compound 3, half-maximal inhibitory concentration: 280 nM
Beside the measured number, compound 3's estimate is 1.6-fold (0.21 log units) above it; the range from low to high includes it.
By their numbers in this assay, from the lowest: compounds 3 and 2 (each within the scatter of the next); then compound 1.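

In this assay, methoxy in place of ethyl gives a 1.2-fold lower number from compound 2 to compound 3 (0.07 log units; within the scatter), so on this chain the oxygen, with its one hydrogen-bond acceptor, brings no readable difference. On the aromatic nitrogen, 2-methoxyethyl in place of cyclopropyl gives a 3.1-fold lower number from compound 1 to compound 3 (0.49 log units; beyond the scatter), which adds a second open chain to butyl that differs from cyclopropyl beyond the scatter. No supporting data explain this result.

Still open, on these data alone, is whether an amine or a carboxylic acid in place of the methoxy would hold these numbers. A longer chain, such as 3-methoxypropyl, is equally unresolved.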